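Urea aryl variation in a pyrazole series: chloro to trifluoromethyl

The source may report more compounds than this note shows. Statements on the series, on what has been measured and on what is new or still open speak of the compounds shown alone.

Measured so far:
compound 1 `COc1cc(-c2nn(-c3cccc(NC(=O)Nc4cc(C(F)(F)F)cc(C(F)(F)F)c4)c3)cc2-c2ccncc2)ccc1Cl` — 399 nM
compound 2 `COc1cc(-c2nn(-c3cccc(NC(=O)Nc4ccc(Cl)c(Cl)c4)c3)cc2-c2ccncc2)ccc1Cl` — 691 nM
compound 3 `O=C(Nc1cccc(-n2cc(-c3ccncc3)c(-c3ccc(Cl)c(O)c3)n2)c1)Nc1cc(C(F)(F)F)cc(C(F)(F)F)c1` — 618 nM

In a functional assay on SF-295 cells (Homo sapiens) for inhibition, read by sulforhodamine B assay, with a stated time of 48 h (on this read-out higher numbers stand for weaker inhibition of growth and lower numbers for stronger inhibition of growth), compound 2 gives the highest of the three numbers, yet it sits within the scatter of both compound 3 and compound 1. Compound 4 `COc1cc(-c2nn(-c3cccc(NC(=O)Nc4ccc(Cl)c(C(F)(F)F)c4)c3)cc2-c2ccncc2)ccc1Cl` differs from compound 2 by trifluoromethyl in place of chloro on an aromatic carbon. Among the compounds with values here, the only step that has been measured, a 1.5-fold higher number from compound 1 to compound 3 (0.19 log units; within the scatter), concerns the oxygen substituent on the other end of the core and does not bear on the urea aryl. What compound 1 and compound 2 show, two trifluoromethyl groups against two chloro groups, is a gap within the scatter. Compound 4 lies between those two patterns, so only a step within the scatter is expected, a 1.3-fold lower number from compound 2 to compound 4 (0.12 log units; within the scatter), and compound 4 is estimated at 520 nM, between 250 nM and 1100 nM.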

Compound 4, concentration for 50% growth inhibition: 840 nM
Estimate against measurement, compound 4: 1.6-fold (0.21 log units) below; low and high end bracket the measured number.
By their numbers in this assay, from the lowest: compounds 1, 3, 2 and 4 (each within the scatter of the next, the first and the last beyond it).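

In this assay, within the data shown here, trifluoromethyl in place of chloro, ortho to a chloro group, gives a 1.2-fold higher number from compound 2 to compound 4 (0.08 log units; within the scatter) as the first measured step on the urea aryl. At this position, in this pair, four heavy atoms replacing one leave the read-out within the scatter. No evidence bearing on this result is available. On these data alone, how a nitrile or an amine would read at this position remains open. Also open, as far as these compounds go, is whether the same exchange reads alike when the methoxy on the other aryl ring is a hydroxy group.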